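Fluorophenyl placement on the piperazine nitrogen of the chloro series

The compounds below may be only part of what the source reports. "The series", "measured", "known", "first", "only" and "open" are said of these compounds alone.

Compound 3 `O[C@H](COc1ccc(Cl)cc1)CN1CCN(c2ccc(F)cc2)CC1` is the reference point for this step. Among the compounds with values here, in an assay on HEK293 cells for inhibition of Voltage-dependent T-type calcium channel subunit alpha-1G (Homo sapiens), read by patch clamp, tested at 10 uM (a higher number here means more inhibition at the concentration tested (going by the name of the read-out), a lower number less inhibition), compound 3 gives 28.3%, the lowest of the three numbers measured so far. Compound 1 `COc1ccccc1N1CCN(C[C@H](O)COc2ccc(Cl)cc2)CC1` gives 48.8% in this assay, and compound 2 `O[C@H](COc1ccc(C(F)(F)F)cc1)CN1CCN(c2ccccc2F)CC1` gives 48.9%. Within the data shown here, the one single-point step recorded runs through the group on the ring nitrogen: a number 20.5 percentage points lower from compound 1 to compound 3 (beyond the scatter), a modest drop beyond the scatter when the 4-fluorophenyl replaces the 2-methoxyphenyl.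

Compound 4 `O[C@H](COc1ccc(Cl)cc1)CN1CCN(c2ccccc2F)CC1` keeps the same atoms as compound 3 but joins them differently: 2-fluorophenyl in place of 4-fluorophenyl on an amine nitrogen in a ring. Among the measured compounds shown here, no recorded step pairs compound 4 with any measured compound, and compound 2 differs from it in the other aryl group as well, so only the two values can be set side by side; compound 2 sits well above compound 3. For the measured compounds named here, the one step that bears on the change in the ring-nitrogen aryl is the drop from compound 1 to compound 3, so for compound 4 a rise of roughly that size is expected in this assay, a number 16.7 percentage points higher from compound 3 to compound 4 (beyond the scatter). Compound 4 is therefore estimated at 45%, within a range of 30% to 60%.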

Compound 4, a percentage reported as inhibition, at one concentration (the size of the read-out at that concentration, not a potency): 35.9%
Estimate against measurement, compound 4: 9.1 percentage points above; measured number inside the range.
By their numbers in this assay, from the lowest: compounds 3 and 4 (each within the scatter of the next); then compounds 1 and 2 (each within the scatter of the next).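

In this assay, 2-fluorophenyl in place of 4-fluorophenyl on the ring nitrogen gives a number 7.6 percentage points higher from compound 3 to compound 4 (within the scatter), so the two fluorophenyl isomers cannot be told apart at this position. Larger changes do register: fluoro in place of methoxy on that aryl ring gives a number 12.9 percentage points lower from compound 1 to compound 4 (beyond the scatter), and chloro in place of trifluoromethyl on the other aryl ring gives a number 13 percentage points lower from compound 2 to compound 4 (beyond the scatter), which shows that both aryl groups affect the read-out in this small set. No measurement available here explains any of these steps.

The compounds shown leave open whether the methoxy and trifluoromethyl steps would add up in one compound. They also leave open how an unsubstituted phenyl, or a nitrile or a carboxylic acid on the ring in place of fluoro, would read in this assay.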